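This account rests on a few compounds, and the source may have more. Where it says the series, first, only, none or still open, it means among the compounds named here.

Measured so far:
compound 1 `CC(C)OC(=O)c1cccc(NC(=O)[C@@H]2C[C@H](SC3=C(C(=O)O)N4C(=O)[C@H]([C@@H](C)O)[C@H]4[C@H]3C)CN2)c1`, in an ADME assay for metabolic stability, read by LC-MS, with a stated time of 3 h, at pH 6.5, tested at 50 uM (a higher number here means that more of the compound is left, a lower number that less of the compound is left), compound 1 gives > 95%, a limit and not a number.
compound 2 `CCOC(=O)c1cccc(NC(=O)[C@@H]2C[C@H](SC3=C(C(=O)O)N4C(=O)[C@H]([C@@H](C)O)[C@H]4[C@H]3C)CN2)c1`, in this assay compound 2 gives > 95%, likewise a limit.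

Both values sit at the limit of > 95% in this assay, at which 2 of the 2 values shown sit, so the step that the two limits leave unreadable from compound 1 to compound 2 cannot be read in size or direction. Compound 2 thus stands at the upper limit, with no number of its own. Compound 3 `C[C@@H](O)[C@H]1C(=O)N2C(C(=O)O)=C(S[C@@H]3CN[C@H](C(=O)Nc4cccc(C(=O)OCC(F)(F)F)c4)C3)[C@H](C)[C@H]12` differs from compound 2 by trifluoromethyl in place of methyl on a saturated chain carbon bound to an oxygen next to a carbonyl group. Going by the values given here, no measured step bears readably on this change. Compound 3 is expected to stay at the limit, an estimated step that the limit leaves unreadable from compound 2 to compound 3. The estimate for compound 3 in this assay is 96%, in the range 88% to 99%.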

Compound 3, percent of the compound remaining: > 95%
Compound 3: no number, only a limit (the forecaster's own chance of this, stated with the estimate: 75%); the middle value lies beyond the limit too.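

Compound 3 gives no readable step against compound 1 or compound 2 in this assay, because all three stand at a limit and not at a number: the limit of > 95% in this assay, at which 3 of the 3 values shown sit.

The compounds shown leave open whether isopropyl, ethyl and 2,2,2-trifluoroethyl differ at all in this assay.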